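The compounds below may be only part of what the source reports. "The series", "measured", "known", "first", "only" and "open" are said of these compounds alone.

Working notes on a thiosemicarbazone series read in a functional assay on A-375 cells (Homo sapiens) for cytotoxicity, read by MTT assay, with a stated time of 72 h, tested at 3 uM; a lower number here means less inhibition of growth, a higher number more inhibition of growth at the concentration tested.

Within the data shown here, compound 1 `N/C(=N\NC(=S)N1CCCCCC1)c1ccccn1` gives 78.6% in this assay, the highest of the three numbers measured so far. Compound 2 `N/C(=N\NC(=S)N1CCOCC1)c1ccccn1` gives 19.3% in this assay. Compound 3 `N/C(=N\NC(=S)N1CCOCC1)c1ccc(F)cn1` gives 66.4% in this assay. The difference between the cores of compound 1 and compound 2 is not broken down here. From compound 2 to compound 3 the change is fluoro in place of hydrogen on an aromatic carbon, and it moves the read-out by a number 47.1 percentage points higher from compound 2 to compound 3 (beyond the scatter). Compound 1 stands nearest to compound 3 and furthest from compound 2, both gaps beyond the scatter.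

Compound 4 `N/C(=N\NC(=S)N1CCCCCC1)c1ccc(F)cn1` has not yet been measured. It arises from compound 1 by fluoro in place of hydrogen on an aromatic carbon, the same change that leads from compound 2 to compound 3; this change appears in two of the pairs shown, and the surroundings of the place are identical in both. The earlier step was large, but it set out from the low read-out of compound 2. Compound 1 already sits high, and the read-out cannot exceed full inhibition of growth, so a smaller step is expected here. Compound 4 is expected to give 86% in this assay, with a range from 72% to 97%. The step this estimate means is a number 7.4 percentage points higher from compound 1 to compound 4 (within the scatter), expected to be smaller than the earlier one because compound 1 starts from 78.6%.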

Compound 4, percent growth inhibition at one concentration: 66.6%
The estimate for compound 4 lay 19.4 percentage points above the measured number; the measured number lies below the stated range.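

In this assay, fluoro in place of hydrogen on an aromatic carbon moves the read-out by a number 12 percentage points lower from compound 1 to compound 4 (beyond the scatter), so on these two cores the change keeps neither its direction nor its size: the same change on two cores in this assay, a number 47.1 percentage points higher (beyond the scatter) from compound 2 to compound 3 and a number 12 percentage points lower (beyond the scatter) from compound 1 to compound 4, 59.1 percentage points apart, beyond the scatter of two such steps

Within this series, then, the step measured on one core cannot be taken as a forecast for the other, and the two fluoro compounds end up with closely similar numbers, compound 3 at 66.4% and compound 4 at 66.6%. Among these compounds, the result does not show why the two steps part, and with only two pairs, one place on the ring and one tested concentration, it gives no rule for any further core.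

The compounds shown leave open whether a group other than fluoro, such as chloro, methoxy or an amine, would also step in opposite directions on the two cores when set on the same carbon, two atoms from the ring nitrogen. They also leave open how the fluoro step would run on a third core, for instance one carrying a longer chain in place of the ring on the thiocarbonyl end.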